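This account rests on a few compounds, and the source may have more. Where it says the series, first, only, none or still open, it means among the compounds named here.

For compound 1 `CC/C(=C(/c1ccc(/C=C/C(=O)O)cc1)c1ccc(O)nc1)c1ccccc1` the result in a functional assay on MCF7 cells (Homo sapiens) for cytotoxicity, read by CellTiter-Glo, with a stated time of 5 days (a lower number here means a stronger inhibitor, a higher number a weaker inhibitor), is "not determined" (no result reported). Compound 2 `CC/C(=C(/c1ccc(/C=C/C(=O)O)cc1)c1ccc2[nH]ccc2c1)c1ccccc1` gives 9 nM in this assay. Compound 3 `CC/C(=C(/c1ccc(/C=C/C(=O)O)cc1)c1ccc2[nH]ncc2c1)c1ccccc1Cl` gives 2 nM in this assay, the lowest of the two numbers available; its nearest neighbour is compound 2, whose number is higher by a margin beyond the usual scatter, while compound 1 stands without a number.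

Compound 4 `CC/C(=C(/c1ccc(/C=C/C(=O)O)cc1)c1ccc2[nH]ncc2c1)c1ccncc1C` is yet to be measured in this assay. It differs from compound 3 in a single place: 3-methylpyridin-4-yl in place of 2-chlorophenyl on a double-bonded chain carbon bound to a double-bonded chain carbon and a saturated chain carbon. No pair of measured compounds differs in this way alone, so the size of the step cannot be read from the data shown. The author expects compound 4 to remain a strong inhibitor because compound 3 gives 2 nM and the exchange keeps the ring count and size unchanged. The step from compound 3 to compound 4 is expected to be a 2.0-fold higher number from compound 3 to compound 4 (0.30 log units; within the scatter), a small weakening that may not exceed the scatter. Compound 4 is estimated at 4 nM, within a range from 1.5 nM to 12 nM.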

Compound 4, half-maximal inhibitory concentration: 16 nM
Compound 4: the middle estimate sits 4.0-fold (0.60 log units) below what was measured, and the stated range ends below it.
By their numbers in this assay, from the lowest: compound 3; then compounds 2 and 4 (each within the scatter of the next).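

In this assay, among the compounds shown here, placing 3-methylpyridin-4-yl in place of 2-chlorophenyl on a double-bonded chain carbon bound to a double-bonded chain carbon and a saturated chain carbon gives an 8.0-fold higher number from compound 3 to compound 4 (0.90 log units; beyond the scatter), the only step at this position that can be read so far. It shows that this position responds to the exchange even though the ring size and the heavy-atom count of the group stay the same, while a ring nitrogen and a hydrogen-bond acceptor enter and chlorine leaves. Nothing measured here accounts for the size of this step.

As far as these compounds go, the exchange alters the ring and its substituent together, so the share of the ring nitrogen, the methyl and the lost chlorine in the step stays open. An unsubstituted pyridine ring, or a methoxy group in place of the methyl, could separate these contributions.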